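A few compounds are considered here, and "the series" means these few. Any claim that something is new, unique, unknown or untested is made for them only; others in the source may bear on it.

Measured in an assay on membranes from Jurkat cells for displacement of a labelled ligand from Sigma non-opioid intracellular receptor 1 (Homo sapiens), read by scintillation counting, with a stated time of 2 h; on this read-out higher numbers stand for weaker inhibition and lower numbers for stronger inhibition:
Compound 1, `Cn1nc(CN2CCCC2)nc1-c1ccc(-c2ccccc2)cc1`: 90 nM
Compound 2, `CCn1nc(CN2CCCC2)nc1-c1ccc(C(C)(C)C)cc1`: 4.8 nM

Of these two, compound 2 gives the lower inhibition constant, and compound 1 stands well beyond the scatter from it. Compound 3, `CC(C)n1nc(CN2CCCC2)nc1-c1ccc(C(C)(C)C)cc1`, is not yet measured. It differs from compound 2 in one place: methyl in place of hydrogen on a saturated chain carbon bound to an aromatic nitrogen and a saturated chain carbon. Nothing measured here tells how this assay answers that kind of change. The step from compound 2 to compound 3 is therefore expected to be small, within the scatter, with no clear direction, as a 1.1-fold lower number from compound 2 to compound 3 (0.03 log units; within the scatter). Compound 3 is thus estimated at 4.5 nM, in the range 1.5 nM to 14 nM.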

Compound 3, inhibition constant: 2.2 nM
Beside the measured number, compound 3's estimate is 2.0-fold (0.31 log units) above it, and the stated range covers the measured number.
By their numbers in this assay, from the lowest: compound 3; then compound 2; then compound 1.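

In this assay, for the compounds shown here, ethyl to isopropyl at this saturated chain carbon bound to an aromatic nitrogen gives a 2.2-fold lower number from compound 2 to compound 3 (0.34 log units; beyond the scatter) and so is the first reading of this change, showing that inhibition here answers modestly to the added methyl and does not weaken. This is a single step, so it sets no pattern for the position. No supporting evidence bears on why the number moves.

The compounds shown leave open whether a longer chain such as n-propyl or a ring such as cyclopropyl at this place would continue the step. They also leave open whether the same change would read alike on the core of compound 1.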